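A few compounds are considered here, and "the series" means these few. Any claim that something is new, unique, unknown or untested is made for them only; others in the source may bear on it.

Compounds measured in a functional assay on MDA-MB-231 cells (Homo sapiens) for cytotoxicity, read by MTT assay, with a stated time of 48 h; on this read-out lower numbers stand for stronger inhibition and higher numbers for weaker inhibition:

- compound 1, `O=C1Nc2ccc(Cl)cc2C1(c1c(-c2ccccc2)[nH]c2ccccc12)c1c(-c2ccccc2)[nH]c2ccccc12`: > 100000 nM
- compound 2, `Cc1[nH]c2ccc([N+](=O)[O-])cc2c1C1(c2c(C)[nH]c3ccc([N+](=O)[O-])cc23)C(=O)Nc2ccccc21`: 99400 nM
- compound 3, `Cc1[nH]c2ccccc2c1C1(c2c(C)[nH]c3ccccc23)C(=O)Nc2ccccc21`: > 100000 nM

Three compounds share a core in which two indole units hang from the same carbon of a lactam ring. Compound 1 reaches only a limit of this assay, > 100000 nM, not a measured number. Compound 3 likewise stops at a limit, > 100000 nM. Going by the values given here, compound 2, which carries a nitro group on each indole, is the one compound for which a number is known, 99400 nM, and that number lies close to the limit of > 100000 nM in this assay, at which 2 of the 3 values shown sit.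

Compound 4, `Cc1[nH]c2ccc([N+](=O)[O-])cc2c1C1(c2c(C)[nH]c3ccc([N+](=O)[O-])cc23)C(=O)Nc2ccc(Cl)cc21`, has not yet been measured. It differs from compound 2 in one place: chloro in place of hydrogen on an aromatic carbon. Among the measured compounds there is no pair that differs only in this way, so no measured step shows what this change does. Compound 2 is expected to give only a small step, a 1.1-fold lower number from compound 2 to compound 4 (0.04 log units; within the scatter), with the result quite possibly falling again at a limit of this assay. Compound 4 is therefore estimated at 90000 nM, within a range from 30000 nM to 300000 nM.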

Compound 4, half-maximal inhibitory concentration: 10100 nM
Compound 4: middle estimate off by 8.9-fold (0.95 log units), on the high side, outside the stated range (below it).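

In this assay, chloro in place of hydrogen on this aromatic carbon gives a 9.8-fold lower number from compound 2 to compound 4 (0.99 log units; beyond the scatter), so a single added chlorine atom at this position moves the result beyond the scatter. Compound 4 gives a measured number, 10100 nM. This is the only step in the set that can be read, and the earlier compounds could not show it because the others stop at a limit and offer no number to compare: the limit of > 100000 nM in this assay, at which 2 of the 4 values shown sit.

From the compounds shown here alone, a single pair speaks for this position, so it remains open whether chloro has the same effect on a compound without the nitro groups. Also open, going by these compounds, is what a different group on this carbon, such as bromo, methoxy or an amine, would do.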